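Removing an N-Methyl Group on a Sulfonylurea: Predicting Compound 4

A few compounds are considered here, and "the series" means these few. Any claim that something is new, unique, unknown or untested is made for them only; others in the source may bear on it.

Compound 1 `Cc1ccc(S(=O)(=O)N(C)C(=O)NC(C)c2cc(Br)ccc2OCc2ccccc2)cc1` and compound 2 `Cc1ccc(S(=O)(=O)NC(=O)NC(C)c2cc(Br)ccc2OCc2ccccc2)cc1` differ only in one spot, (hydrogen in place of methyl on an amide-type nitrogen). In a functional assay on thoracic aorta (Rattus norvegicus, strain Wistar), with a stated time of 15 min (a higher number here means that more compound is needed for the effect, a lower number that less compound is needed), compound 1 gives 67100 nM, and compound 2 gives 138000 nM, so the change produced a 2.1-fold higher number from compound 1 to compound 2 (0.31 log units; beyond the scatter). Compound 3 `CC(C)Oc1ccc(Br)cc1C(C)NC(=O)N(C)S(=O)(=O)c1ccc(Cl)cc1` carries a different core; how its core differs from that of compound 1 is not broken down here. In this assay compound 3 gives 43200 nM. Compound 4 `CC(C)Oc1ccc(Br)cc1C(C)NC(=O)NS(=O)(=O)c1ccc(Cl)cc1` is related to compound 3 by the same change, (hydrogen in place of methyl on an amide-type nitrogen), at a place that reads the same in both pairs. Going from compound 3 to compound 4, the step is expected to be a 2.1-fold higher number from compound 3 to compound 4 (0.32 log units; beyond the scatter), because the earlier pair showed a 2.1-fold higher number from compound 1 to compound 2 (0.31 log units; beyond the scatter). Compound 4 is therefore estimated at 90000 nM, likely between 45000 nM and 180000 nM.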

Compound 4, half-maximal effective concentration: 122000 nM
Beside the measured number, compound 4's estimate is 1.4-fold (0.13 log units) below it, within the range that was stated.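

In this assay putting hydrogen in place of methyl on the amide-type nitrogen gives a 2.8-fold higher number from compound 3 to compound 4 (0.45 log units; beyond the scatter) and this step matches the one on the other core in direction, with no difference in size beyond the scatter: the same change on two cores in this assay, a 2.1-fold higher number (0.31 log units; beyond the scatter) from compound 1 to compound 2 and a 2.8-fold higher number (0.45 log units; beyond the scatter) from compound 3 to compound 4, 1.4-fold (0.14 log units) apart, within the scatter of two such steps. In this pair of cores, then, the change carries over from one core to the other. Among the compounds shown here, this rests on only two pairs in a single assay, so it does not show that the step would hold on other cores, nor does it explain why removing the methyl has this effect.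

The compounds shown leave open what an ethyl group or a longer chain on this nitrogen would do. They also leave open whether the step keeps its size on a core carrying an amine or a carboxylic acid.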